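The compounds below may be only part of what the source reports. "The series", "measured", "known", "first", "only" and "open" are said of these compounds alone.

Of the compounds shown here, three sharing one core have been measured in an assay for inhibition of serine/threonine-protein kinase 3 (Homo sapiens), read by luminescence and ADP-Glo, in the presence of a further agent that is not named here; a lower number here means a stronger inhibitor, a higher number a weaker inhibitor. Compound 1 `OCCCNc1ncnc2[nH]cc(-c3cccc(Cl)c3)c12` gives 173 nM. Compound 2 `CNC1CCN(c2ncnc3[nH]cc(-c4cccc(Cl)c4)c23)CC1` gives 293 nM. Compound 3 `CN(C)c1ncnc2[nH]cc(-c3cccc(Cl)c3)c12` gives 349 nM. Compound 2 sits between the other two on these numbers, and both of its neighbours lie close: the step of a 1.7-fold higher number from compound 1 to compound 2 (0.23 log units; within the scatter) and the step of a 1.2-fold higher number from compound 2 to compound 3 (0.08 log units; within the scatter) are each within the scatter, so the three compounds cannot be told apart on this evidence.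

Compound 4 `Clc1cccc(-c2c[nH]c3ncnc(NCC4CC4)c23)c1` has not yet been measured in this assay. It differs from compound 2 in one place: (cyclopropylmethyl)amino in place of 4-(methylamino)piperidin-1-yl on an aromatic carbon. The measured steps that speak to this change are those that also swap the group on that aromatic carbon. The step of a 1.7-fold higher number from compound 1 to compound 2 (0.23 log units; within the scatter) removes a (3-hydroxypropyl)amino group in favour of the 4-(methylamino)piperidin-1-yl group, and the step of a 2.0-fold higher number from compound 1 to compound 3 (0.30 log units; within the scatter) replaces the same (3-hydroxypropyl)amino with dimethylamino; neither moves beyond the scatter. Compound 4 carries a (cyclopropylmethyl)amino group, which like the group of compound 1 keeps one hydrogen-bond donor on that carbon, so no step beyond the scatter is expected in either direction. Compound 4 is expected to give about 200 nM, with a likely range from 80 nM to 500 nM. This estimate means an expected step of a 1.5-fold lower number from compound 2 to compound 4 (0.17 log units; within the scatter).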

Compound 4, half-maximal inhibitory concentration: 213 nM
The estimate for compound 4 lay 1.1-fold (0.03 log units) below the measured number, within the range that was stated.
By their numbers in this assay, from the lowest: compounds 1, 4, 2 and 3 (each within the scatter of the next).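

In this assay this position accepts a fourth group without any step beyond the scatter: compared with the piperidine group (a 1.4-fold lower number from compound 2 to compound 4 (0.14 log units; within the scatter)), with the dimethylamino group (a 1.6-fold lower number from compound 3 to compound 4 (0.21 log units; within the scatter)) and with the (3-hydroxypropyl)amino group (a 1.2-fold higher number from compound 1 to compound 4 (0.09 log units; within the scatter)), the number does not separate. Going from 4-(methylamino)piperidin-1-yl to (cyclopropylmethyl)amino replaces a group of 8 heavy atoms and a six-membered non-aromatic ring with a group of 5 heavy atoms and a three-membered ring of carbon only, yet the reading stays within the scatter, and the same holds when cyclopropyl takes the place of the 2-hydroxyethyl part of the chain in compound 1. Nothing measured here explains why these different groups read alike. The compounds shown leave open whether any group on this aromatic carbon can move the number beyond the scatter, which a carboxylic acid, an unsubstituted amine or a much longer carbon chain there could test. All four compounds differ only at this one place, so they say nothing about changes elsewhere on the shared core.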